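The source may report more compounds than this note shows. Statements on the series, on what has been measured and on what is new or still open speak of the compounds shown alone.

Measured so far:
compound 1 `COc1ccc(/C=N/NC(=O)Nc2ccc(Oc3ccnc4cc(OCCCN5CCCCC5)c(OC)cc34)c(F)c2)cc1` gives 660 nM
compound 2 `COc1cc2c(Oc3ccc(NC(=O)N/N=C/c4ccc(F)cc4Cl)cc3F)ccnc2cc1OCCCN1CCCCC1` gives 270 nM
compound 3 `COc1cc2c(Oc3ccc(NC(=O)N/N=C/c4cc5ccccc5[nH]4)cc3F)ccnc2cc1OCCCN1CCCCC1` gives 830 nM

In a functional assay on MKN-45 cells (Homo sapiens) for cytotoxicity, read by MTT assay, with a stated time of 72 h (a lower number here means a stronger inhibitor, a higher number a weaker inhibitor), compound 3 has the highest number of the three: one step is a 1.3-fold higher number from compound 1 to compound 3 (0.10 log units; within the scatter), while the other step is a 3.1-fold higher number from compound 2 to compound 3 (0.49 log units; beyond the scatter). Compound 4 `COc1cc2c(Oc3ccc(NC(=O)N/N=C/c4cccs4)cc3F)ccnc2cc1OCCCN1CCCCC1` differs from compound 3 by thiophen-2-yl in place of 1H-indol-2-yl on a carbon with a double bond to nitrogen. Among the measured compounds shown here, no measured step swaps in a five-membered ring at this carbon, so the nearest guides are the other swaps there, a 2.4-fold lower number from compound 1 to compound 2 (0.39 log units; beyond the scatter) and a 3.1-fold higher number from compound 2 to compound 3 (0.49 log units; beyond the scatter), both modest. A modest step is therefore expected, most likely downward toward the numbers of compound 1 and compound 2. Compound 4 is expected to give 600 nM, with a range of 250 nM to 1500 nM, meaning an estimated step of a 1.4-fold lower number from compound 3 to compound 4 (0.14 log units; within the scatter).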

Compound 4, half-maximal inhibitory concentration: 740 nM
Compound 4: the middle estimate sits 1.2-fold (0.09 log units) below what was measured; measured number inside the range.
By their numbers in this assay, from the lowest: compound 2; then compounds 1, 4 and 3 (each within the scatter of the next).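

In this assay, thiophen-2-yl, with 5 heavy atoms and no hydrogen-bond donor, performs like the larger 1H-indol-2-yl (a 1.1-fold lower number from compound 3 to compound 4 (0.05 log units; within the scatter)) and like 4-methoxyphenyl (a 1.1-fold higher number from compound 1 to compound 4 (0.05 log units; within the scatter)). At this carbon, then, only 2-chloro-4-fluorophenyl stands apart from the other three groups (a 2.7-fold higher number from compound 2 to compound 4 (0.44 log units; beyond the scatter)). No measurement shown here offers a reason for that gap.

Still open, from the compounds shown here alone, is whether a furan-2-yl or pyridin-2-yl ring would behave like thiophen-2-yl, and whether a phenyl ring carrying only chlorine or only fluorine would keep the lower number of compound 2.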